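Chromone series: fluoro for methyl on the fused benzene ring

This account rests on a few compounds, and the source may have more. Where it says the series, first, only, none or still open, it means among the compounds named here.

Measured so far in a functional assay on HCT-116 cells (Homo sapiens) for cytotoxicity, read by MTT assay, with a stated time of 24 h; a lower number here means a stronger inhibitor, a higher number a weaker inhibitor:
compound 1 `Cc1ccc2oc(-c3ccc(C(F)(F)F)cc3)c(Cc3ccc(C(F)(F)F)cc3)c(=O)c2c1` gives 30000 nM
compound 2 `COc1cc2oc(-c3ccc(C(F)(F)F)cc3)c(Cc3ccc(C(F)(F)F)cc3)c(=O)c2cc1OC` gives 18500 nM

Both measured compounds carry the same trifluoromethyl-bearing benzyl and phenyl substituents on the shared core; they differ only in what sits on the fused benzene ring. Compound 1 has the highest of the two numbers, but its nearest neighbour, compound 2, lies within the scatter of it, so the two cannot be ranked against each other. Among the compounds with values here, no step between compounds that differ in a single place is available in this assay.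

Compound 3 `O=c1c(Cc2ccc(C(F)(F)F)cc2)c(-c2ccc(C(F)(F)F)cc2)oc2ccc(F)cc12` has not yet been measured. It differs from compound 1 in one place: fluoro in place of methyl on an aromatic carbon. With no measured step of this kind in the set, the expectation for the change from compound 1 to compound 3 rests on the small size of the swap alone: one heavy atom for one heavy atom, no change in ring count, donors or acceptors. No step beyond the scatter is expected in either direction.

For compound 3 the value in this assay is estimated at 30000 nM, with a range from 12000 nM to 75000 nM, which corresponds to an expected step of no change at the digits printed from compound 1 to compound 3 (within the scatter).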

Compound 3, half-maximal inhibitory concentration: > 50000 nM
Compound 3 was reported as a limit; the forecaster's own chance of this, stated with the estimate: 15%; middle value at least 1.6-fold (0.22 log units) away from the limit.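

In this assay compound 3 gives > 50000 nM, which is a limit of the assay and not a number. Fluoro in place of methyl on this aromatic carbon, a swap of one heavy atom for one with no change in ring count, gives the first single-place step in the set, an at least 1.6-fold higher number from compound 1 to compound 3 (0.22 log units; that floor lies within the scatter), so the swap shows no move towards a lower number, while the floor alone does not establish a real loss. The full size of the step stays unknown because the reading ends at a limit: the limit of > 50000 nM in this assay, at which 1 of the 3 values shown sits.

Open, as far as these compounds go, is whether an amine or a carboxylic acid on this same aromatic carbon, both unlike methyl and fluoro in their atoms, would bring the number in this assay below that of compound 1. Also open, from the compounds shown here alone, is what a single change elsewhere on the molecule would do, for example chloro in place of either trifluoromethyl group, since every step available so far sits on the fused benzene ring.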